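Oxetane to thietane to thietane oxide: one step forward

The compounds below may be only part of what the source reports. "The series", "measured", "known", "first", "only" and "open" are said of these compounds alone.

Compound 1 `CC(C)Cc1ccc(C(C)C2(O)COC2)cc1` in an assay on cells for inhibition of Polyunsaturated fatty acid 5-lipoxygenase (Rattus norvegicus), read by LC-MS, with stated times of 2 h and 15 min; a lower number here means a stronger inhibitor, a higher number a weaker inhibitor: 8400 nM
Compound 2 `CC(C)Cc1ccc(C(C)C2(O)CSC2)cc1` in this assay: 7600 nM

Of the compounds shown here, two sharing the same core have been measured in this assay. Compound 2 stands alongside compound 1: the step of a 1.1-fold lower number from compound 1 to compound 2 (0.04 log units; within the scatter) is within the scatter, so neither can be called the stronger inhibitor on these numbers.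

Compound 3 `CC(C)Cc1ccc(C(C)C2(O)C[S+]([O-])C2)cc1` is not yet measured. It differs from compound 2 by a group of 6 heavy atoms (3 carbon, 2 oxygen, 1 sulfur; one four-membered non-aromatic ring with 1 hetero atom) in place of a group of 5 heavy atoms (3 carbon, 1 oxygen, 1 sulfur; one four-membered non-aromatic ring with 1 hetero atom), on a saturated chain carbon bound to an aromatic carbon and a saturated chain carbon. Within the data shown here, the only measured step, from compound 1 to compound 2, also exchanged the four-membered ring at this same place, and it produced no shift beyond the scatter. That step does not reproduce the present change, so the basis for a forecast is thin. Among the measured compounds shown here, with no measured step pointing in either direction, no change beyond the scatter is expected in this assay for compound 3, and a broad range is kept because the change itself is unprecedented here.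

Compound 3 is therefore estimated at 9000 nM, with a range from 3000 nM to 30000 nM, which corresponds to an expected step of a 1.2-fold higher number from compound 2 to compound 3 (0.07 log units; within the scatter).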

Compound 3, half-maximal inhibitory concentration: 11700 nM
Beside the measured number, compound 3's estimate is 1.3-fold (0.11 log units) below it; the measured number falls inside the stated range.
By their numbers in this assay, from the lowest: compounds 2, 1 and 3 (each within the scatter of the next).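

In this assay, the group with 6 heavy atoms at this place, on a saturated chain carbon bound to an aromatic carbon and a saturated chain carbon, gives two new steps: a 1.5-fold higher number from compound 2 to compound 3 (0.19 log units; within the scatter) and a 1.4-fold higher number from compound 1 to compound 3 (0.14 log units; within the scatter). Adding an oxygen to the sulfur-bearing ring thus adds a second kind of change at this place, and it too stays within the scatter, so compounds 1, 2 and 3 cannot be ranked against one another. No supporting data bear on why these numbers lie so close together.

On these data alone, whether an amine or a carboxylic acid in place of the four-membered ring would move the number beyond the scatter remains open. So does whether a longer chain on the shared core would do so.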